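From compound 2 to compound 4: amino replaces nitro

This account rests on a few compounds, and the source may have more. Where it says the series, first, only, none or still open, it means among the compounds named here.

For the measured compounds named here, in a functional assay on P388 cells (Mus musculus) for inhibition (a higher number here means a weaker inhibitor, a lower number a stronger inhibitor), compound 1 (`Oc1ccc(/C=C/c2ccc3ccccc3c2)cc1`) gives 4060 nM, the only reading so far that is a number. Compound 2 (`COc1cc(/C=C/c2ccc(N(C)C)c([N+](=O)[O-])c2)cc(OC)c1OC`) reads > 5000 nM, which is a limit and not a number. Compound 3 (`COc1cc(/C=C\c2ccc(N(C)C)c([N+](=O)[O-])c2)cc(OC)c1OC`) reads > 5000 nM, again a limit. Compound 2 therefore has no exact place in this assay.

Going by the values given here, the one measured step is a step that the two limits leave unreadable from compound 2 to compound 3. It rests on the limit of > 5000 nM in this assay, at which 2 of the 3 values shown sit, and on (the fact that compounds 2 and 3 differ only in the configuration as drawn), and it gives no size to carry forward.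

Compound 4 (`COc1cc(/C=C/c2ccc(N(C)C)c(N)c2)cc(OC)c1OC`) has amino in place of nitro on an aromatic carbon, ortho to a dimethylamino group and meta to a large group: amino in place of nitro on an aromatic carbon. Among the compounds with values here, no measured step covers this exchange, so the data fix neither its size nor its direction. Starting from the limit of compound 2, only a move towards a stronger inhibitor could yield a number. A reading in the region of compound 1, at 4060 nM, is the working expectation. For compound 4 a second limit remains about as likely. The expected step is an at least 1.6-fold lower number from compound 2 to compound 4 (0.22 log units; that floor lies within the scatter). For compound 4 the estimated value is 3000 nM, with an expected range of 400 nM to 9000 nM.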

Compound 4, half-maximal inhibitory concentration: 1520 nM
Estimate against measurement, compound 4: 2.0-fold (0.30 log units) above, and the stated range covers the measured number.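

In this assay, for the compounds shown here, the aromatic carbon ortho to a dimethylamino group is the first place where a single exchange gives a readable step: amino in place of nitro, which swaps a group with no hydrogen-bond donor for one that has one, gives an at least 3.2-fold lower number from compound 2 to compound 4 (0.51 log units; beyond the scatter). Compound 2 reads > 5000 nM, which is a limit and not a number. The step therefore fixes the direction of this exchange and only a floor for its size, and the full size stays unknown because one end of the step is that limit: the limit of > 5000 nM in this assay, at which 2 of the 4 values shown sit.

Going by these compounds, whether the lower number follows from amino itself or simply from the loss of nitro stays open, and a methylamino group, an acetamide or a carboxylic acid on the same aromatic carbon would help to separate the two readings. On these data alone, the step from compound 2 to compound 3 cannot be read, so the weight of the double-bond configuration also remains open.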